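A Fluorine for a Methyl on the Amide Nitrogen

This account rests on a few compounds, and the source may have more. Where it says the series, first, only, none or still open, it means among the compounds named here.

Three measured compounds share one core, carrying an amide-linked aryl group on one side and a ring nitrogen with either an aryl or a pentyl group on the other. Compound 1 `Cc1ccc(NC(=O)c2cccc(/C=C3\CC(=O)N(c4ccccc4)C3=O)c2)cc1` bears a phenyl on that ring nitrogen. In an ADME assay on SW480 cells (Homo sapiens) for cytotoxicity, read by MTT assay, with a stated time of 72 h (a higher number here means a weaker inhibitor, a lower number a stronger inhibitor), compound 1 reaches only > 100000 nM, which is a limit of the assay and not a number. Compound 2 `CCCCCN1C(=O)C/C(=C\c2cccc(C(=O)Nc3ccc(C)cc3)c2)C1=O` carries a pentyl there instead. In this assay compound 2 likewise stops at > 100000 nM, again a limit of the assay. The step that the two limits leave unreadable from compound 1 to compound 2 therefore cannot be read. For the measured compounds named here, compound 3 `CCc1cccc(NC(=O)c2cccc(/C=C3\CC(=O)N(c4ccc(C)cc4)C3=O)c2)c1` is the only one with a number, giving 65300 nM in this assay. Two of the three values sit at the point where the assay stops reading (the limit of > 100000 nM in this assay, at which 2 of the 3 values shown sit), and the number for compound 3 is not far from that point.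

Compound 4 `CCCCCN1C(=O)C/C(=C\c2cccc(C(=O)Nc3cccc(F)c3)c2)C1=O` is not yet measured. It differs from compound 2 by 3-fluorophenyl in place of 4-methylphenyl on an amide-type nitrogen. Going by the values given here, no measured pair shows this particular exchange, so no step bears on it directly; what is known is that two of three values sit at the limit of > 100000 nM in this assay, at which 2 of the 3 values shown sit, and the third lies near it. Compound 4 is therefore expected to remain near that limit, with the estimated step of a number no higher from compound 2 to compound 4 (the limit leaves the size open) adding nothing beyond the scatter. The estimated value for compound 4 in this assay is 100000 nM, between 50000 nM and 200000 nM.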

Compound 4, half-maximal inhibitory concentration: > 100000 nM
Compound 4 was reported as a limit; the forecaster's own chance of this, stated with the estimate: 60%; the middle value lies on the limit itself.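

In this assay compound 4 gives > 100000 nM, which is a limit of the assay and not a number. Compound 2 also stands at such a limit, so the step between compound 2 and compound 4 cannot be read. The compounds shown leave open whether exchanging 4-methylphenyl for 3-fluorophenyl on the amide-type nitrogen changes cytotoxicity at all.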